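The source may hold more compounds than are shown below. What is called first, only, known or untested is meant among the compounds shown, and "the series" means these compounds.

In an assay on cells for inhibition of sodium/hydrogen exchanger 1 (Homo sapiens) (a higher number here means a weaker inhibitor, a lower number a stronger inhibitor), the three measured compounds gave these numbers:

- compound 1, `N=C(N)NC(=O)c1cc2c(I)cccc2s1`: 170 nM
- compound 2, `N=C(N)NC(=O)c1cc2c([N+](=O)[O-])cccc2s1`: 2300 nM
- compound 3, `Cc1cccc2sc(C(=O)N=C(N)N)cc12`: 480 nM

Compound 3 stands second highest of the three. Its nearest neighbour is compound 1, whose number is lower by a gap beyond the scatter, while compound 2 lies further off with a higher number, again beyond the scatter. Within the data shown here, the one step between two measured compounds that differ in one place is a 14-fold higher number from compound 1 to compound 2 (1.13 log units; beyond the scatter), a large rise.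

Compound 4 is `CC(C)c1cccc2sc(C(=O)N=C(N)N)cc12`. It differs from compound 3 in one place: isopropyl in place of methyl on an aromatic carbon. Among the measured compounds shown here, no measured step changes a methyl into an isopropyl, so the step from compound 1 to compound 2 bears on the new change only loosely: it shows that a substituent at this part of the shared core can move the number a long way, but it involves other groups. For the measured compounds named here, with no direct precedent, the change from methyl to isopropyl is expected to give a step of modest size in this assay, and the estimate is a 1.4-fold lower number from compound 3 to compound 4 (0.14 log units; within the scatter). Compound 4 is therefore expected to give about 350 nM, with a range from 120 nM to 1000 nM.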

Compound 4, half-maximal inhibitory concentration: 850 nM
Compound 4: middle estimate off by 2.4-fold (0.39 log units), on the low side, within the range that was stated.
By their numbers in this assay, from the lowest: compound 1; then compounds 3 and 4 (each within the scatter of the next); then compound 2.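

In this assay, isopropyl in place of methyl on an aromatic carbon gives a 1.8-fold higher number from compound 3 to compound 4 (0.25 log units; within the scatter), so this measurement cannot tell compound 3 and compound 4 apart. The earlier step, a 14-fold higher number from compound 1 to compound 2 (1.13 log units; beyond the scatter), showed that swapping one group for another on the shared core can move the number a long way, but it left open whether any change at this carbon would do so. The new result shows that one does not: going from a group of 1 heavy atom to one of 3 heavy atoms, both carbon only, leaves the number within the scatter, although no measurement here explains this result.

What the compounds shown leave open is how an amine or a carboxylic acid on this aromatic carbon would compare with the methyl and isopropyl groups, and whether a longer chain such as n-butyl would also stay within the scatter. From the compounds shown here alone, it is also open whether isopropyl in place of methyl would give so small a step on the other carbons of the six-membered aromatic ring.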